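The source may hold more compounds than are shown below. What is called first, only, known or untested is meant among the compounds shown, and "the series" means these compounds.

Of the compounds shown here, three on a shared core have been measured in a functional assay on HCT-15 cells (Homo sapiens) for inhibition; on this read-out lower numbers stand for stronger inhibition and higher numbers for weaker inhibition. Compound 1 `Oc1ccc(-c2cc(-c3ccccc3F)cc(-c3ccccc3O)n2)cc1` gives > 50000 nM, which is a limit of the assay rather than a number, namely (the limit of > 50000 nM in this assay, at which 1 of the 3 values shown sits). Going by the values given here, compound 2 `Oc1ccc(-c2cc(-c3ccccc3C(F)(F)F)cc(-c3ccccc3O)n2)cc1` gives 8990 nM, and the step of an at least 5.5-fold lower number from compound 1 to compound 2 (0.74 log units; beyond the scatter) is the only measured single-point change in the set. Compound 3 `Oc1cccc(-c2cc(-c3ccccc3OC(F)(F)F)cc(-c3ccccc3O)n2)c1` gives 3240 nM, the lowest of the two numbers recorded, with compound 2 as its nearest neighbour at a higher value that lies beyond the scatter. Compound 4 `Oc1ccc(-c2cc(-c3ccccc3OC(F)(F)F)cc(-c3ccccc3O)n2)cc1` has not yet been measured; it differs from compound 3 by 4-hydroxyphenyl in place of 3-hydroxyphenyl on an aromatic carbon. Among the compounds with values here, the one measured step concerns a different position and does not bear on this change, and compounds 1 and 2, which carry the 4-hydroxyphenyl group, differ from compound 3 in a second place as well, so no step isolates the hydroxyphenyl pattern. Compound 4 is therefore expected to show no step beyond the scatter, a 1.1-fold higher number from compound 3 to compound 4 (0.03 log units; within the scatter). Compound 4 is estimated at 3500 nM, between 1200 nM and 10000 nM.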

Compound 4, half-maximal inhibitory concentration: 9820 nM
The estimate for compound 4 lay 2.8-fold (0.45 log units) below the measured number; measured number inside the range.
By their numbers in this assay, from the lowest: compound 3; then compounds 2 and 4 (each within the scatter of the next). At a limit, above all of these: compound 1.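

Going by these compounds alone, this is the first measured read on the hydroxyphenyl pattern at this place, next to the ring nitrogen: in this assay, 4-hydroxyphenyl in place of 3-hydroxyphenyl gives a 3.0-fold higher number from compound 3 to compound 4 (0.48 log units; beyond the scatter), so the hydroxyl pattern matters here, at least with trifluoromethoxy on the shared core. With 4-hydroxyphenyl kept, trifluoromethoxy in place of trifluoromethyl gives a 1.1-fold higher number from compound 2 to compound 4 (0.04 log units; within the scatter), so those two groups are not told apart, while trifluoromethoxy in place of fluoro gives an at least 5.0-fold lower number from compound 1 to compound 4 (0.70 log units; beyond the scatter). That last step rests on compound 1, whose > 50000 nM is a limit and not a number: the limit of > 50000 nM in this assay, at which 1 of the 4 values shown sits.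

Going by these compounds, whether 3-hydroxyphenyl also gives a lower number than 4-hydroxyphenyl alongside trifluoromethyl or fluoro remains open. Also open, on these data alone, is how an amine or a carboxylic acid in place of the hydroxyl at this place would read in this assay.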